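This account rests on a few compounds, and the source may have more. Where it says the series, first, only, none or still open, it means among the compounds named here.

Measured so far in a functional assay on the whole organism (artery, strain albino) with Rattus norvegicus as the target, with a stated time of 240 min, at a dose of 10 mg/kg by the oral route; a higher number here means more inhibition at the dose given (going by the name of the read-out), a lower number less inhibition:
compound 1, `CC1=C(C(=O)Nc2ccc(Br)cc2)C(c2ccc(Cl)cc2Cl)N=C(SCc2ccccc2)N1`, gives 17.4%
compound 2, `CC1=C(C(=O)Nc2ccc(Br)cc2)C(c2ccc(Cl)cc2Cl)N=C(SCc2cccc(Cl)c2)N1`, gives 15.9%
compound 3, `COc1ccc(C2N=C(SCc3ccccc3)NC(C)=C2C(=O)Nc2ccc(Br)cc2)cc1`, gives 13.3%

Compound 3 holds the lowest of the three numbers, yet neither gap separates it from the others: a number 4.1 percentage points lower from compound 1 to compound 3 (within the scatter), and its distance to compound 2 is likewise within the scatter, so the three stand as one group.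

Compound 4, `COc1ccc(C2N=C(SCc3cccc(Cl)c3)NC(C)=C2C(=O)Nc2ccc(Br)cc2)cc1`, differs from compound 3 by chloro in place of hydrogen on an aromatic carbon. Within the data shown here, one measured step bears directly on this change, made on the 2,4-dichlorophenyl series: a number 1.5 percentage points lower from compound 1 to compound 2 (within the scatter). On that basis no step beyond the scatter is expected for compound 4 in this assay.

Compound 4 is therefore estimated at 12%, with a range from 2% to 22%, which corresponds to an expected step of a number 1.3 percentage points lower from compound 3 to compound 4 (within the scatter).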

Compound 4, a percentage reported as inhibition, in the whole organism at one dose (the size of the read-out at that dose, not a potency): 33.8%
Estimate against measurement, compound 4: 21.8 percentage points below; measured number outside the range, above it.
By their numbers in this assay, from the lowest: compounds 3, 2 and 1 (each within the scatter of the next); then compound 4.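

In this assay, the move from benzyl to 3-chlorobenzyl does not carry over between cores, and with 4-methoxyphenyl on the saturated ring carbon it gives a number 20.5 percentage points higher from compound 3 to compound 4 (beyond the scatter): the same change on two cores in this assay, a number 1.5 percentage points lower (within the scatter) from compound 1 to compound 2 and a number 20.5 percentage points higher (beyond the scatter) from compound 3 to compound 4, 22 percentage points apart, beyond the scatter of two such steps

The aryl change likewise depends on its partner, and with 3-chlorobenzyl in place it gives a number 17.9 percentage points higher from compound 2 to compound 4 (beyond the scatter): the same change on two cores in this assay, a number 4.1 percentage points lower (within the scatter) from compound 1 to compound 3 and a number 17.9 percentage points higher (beyond the scatter) from compound 2 to compound 4, 22 percentage points apart, beyond the scatter of two such steps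

So the two changes cannot be read separately, and among these four compounds only compound 4 combines 4-methoxyphenyl with 3-chlorobenzyl and stands apart from the group.

Going by these compounds, whether fluoro, methoxy or an amine on the same aromatic carbon would behave as chloro does remains open. A single oral dose at one time point also leaves open how the number would move with dose.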